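Trifluoromethoxy in Place of Trifluoromethyl on a Receptor Ligand

A few compounds are considered here, and "the series" means these few. Any claim that something is new, unique, unknown or untested is made for them only; others in the source may bear on it.

Of the compounds shown here, two have so far been measured in an in vitro assay on BHK cells for displacement of a labelled ligand from gastric inhibitory polypeptide receptor (Homo sapiens), read by scintillation proximity assay; a higher number here means a weaker inhibitor, a lower number a stronger inhibitor. Compound 1 `O=C(O)CCNC(=O)c1ccc(CN(c2ccc3c(c2)CCC3)c2nc(-c3ccc(C(F)(F)F)cc3)cs2)cc1` gives 1100 nM in this assay. Compound 2 `O=C(O)CCNC(=O)c1ccc(CC(c2ccc(Cl)cc2)c2nc(-c3ccc(C(F)(F)F)cc3)cs2)cc1` gives 381 nM in this assay, the lowest of the two numbers, and its gap to compound 1 lies beyond the usual scatter. Compounds 1 and 2 differ in more than one place, so their gap says nothing about any single change.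

Compound 3 `O=C(O)CCNC(=O)c1ccc(CC(c2ccc(Cl)cc2)c2nc(-c3ccc(OC(F)(F)F)cc3)cs2)cc1` has not yet been measured in this assay. It differs from compound 2 in one place: trifluoromethoxy in place of trifluoromethyl on an aromatic carbon. No measured pair differs in exactly this way, so there is no direct precedent among these compounds for what the change does on its own.

With nothing to draw on beyond the structural change itself, compound 3 is expected to sit close to compound 2. The step expected is a 1.0-fold higher number from compound 2 to compound 3 (0.02 log units; within the scatter), which is not expected to reach beyond the scatter. Compound 3 is estimated at 400 nM, with a likely range from 150 nM to 1100 nM.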

Compound 3, half-maximal inhibitory concentration: 429 nM
Beside the measured number, compound 3's estimate is 1.1-fold (0.03 log units) below it; the range from low to high includes it.
By their numbers in this assay, from the lowest: compounds 2 and 3 (each within the scatter of the next); then compound 1.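

In this assay the exchange of trifluoromethyl for trifluoromethoxy on an aromatic carbon, para to a large group, gives a 1.1-fold higher number from compound 2 to compound 3 (0.05 log units; within the scatter) and is the first step among these compounds that can be read as a single change. Compounds 2 and 3 cannot be told apart in this assay even though the entering group brings an oxygen, with one more heavy atom and one hydrogen-bond acceptor, so in this pair the 4-(trifluoromethoxy)phenyl group reads the same as the 4-(trifluoromethyl)phenyl group. Nothing measured on hand bears on why the two groups read alike.

The shown compounds leave open whether this place accepts groups of other kinds, such as a nitrile, a methoxy group, an amine or a bare hydrogen, or whether only groups carrying fluorine read like these two. They also leave open whether the same exchange gives a similar step on the core of compound 1, which carries trifluoromethyl in the same place, since this single pair shows the change on the core of compound 2 alone.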